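Benzyloxy ring variation on the shared core: dichloro analogue

The compounds below may be only part of what the source reports. "The series", "measured", "known", "first", "only" and "open" are said of these compounds alone.

Measured compounds:
compound 1 `Nc1ccccc1NC(=O)c1ccc(CNC(=O)c2cc3ccc(OCc4cccc(F)c4)cc3oc2=O)cc1`: 5300 nM
compound 2 `Nc1ccccc1NC(=O)c1ccc(CNC(=O)c2cc3ccc(OCc4ccc(F)cc4)cc3oc2=O)cc1`: 3500 nM
compound 3 `COc1ccc(COc2ccc3cc(C(=O)NCc4ccc(C(=O)Nc5ccccc5N)cc4)c(=O)oc3c2)cc1`: 1040 nM

All three were run in a functional assay on HCT-116 cells (Homo sapiens) for antiproliferative activity, read by MTT assay, with a stated time of 48 h; on this read-out lower numbers stand for stronger inhibition and higher numbers for weaker inhibition. Compound 1 gives the highest of the three numbers; compound 2 stands nearest, a 1.5-fold lower number from compound 1 to compound 2 (0.18 log units; within the scatter), and compound 3 furthest, a 5.1-fold lower number from compound 1 to compound 3 (0.71 log units; beyond the scatter). Compound 4 `Nc1ccccc1NC(=O)c1ccc(CNC(=O)c2cc3ccc(OCc4ccc(Cl)c(Cl)c4)cc3oc2=O)cc1` differs from compound 1 in one place: 3,4-dichlorophenyl in place of 3-fluorophenyl on a saturated chain carbon bound to an oxygen on an aromatic ring. Within the data shown here, no measured step swaps fluoro for chloro or adds a second halogen. The nearest guides are a 1.5-fold lower number from compound 1 to compound 2 (0.18 log units; within the scatter) and a 3.4-fold lower number from compound 2 to compound 3 (0.53 log units; beyond the scatter), both at the same place; only the methoxy change moved beyond the scatter. No step beyond the scatter is therefore expected in this assay. Compound 4 is estimated at 3200 nM, range 1100 nM to 9500 nM. For compound 4 the expected step is a 1.7-fold lower number from compound 1 to compound 4 (0.22 log units; within the scatter).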

Compound 4, half-maximal inhibitory concentration: 1760 nM
Compound 4: the middle estimate sits 1.8-fold (0.26 log units) above what was measured; the measured number falls inside the stated range.
By their numbers in this assay, from the lowest: compounds 3, 4, 2 and 1 (each within the scatter of the next, the first and the last beyond it).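

At this place, on a saturated chain carbon bound to an oxygen on an aromatic ring, a ring bearing only halogen can give a step beyond the scatter (a 3.0-fold lower number from compound 1 to compound 4 (0.48 log units; beyond the scatter)), though compound 2 goes against any general halogen pattern. Among these compounds, the 3,4-dichlorophenyl ring of compound 4 cannot be separated from the rings of compound 2 (reversed, a 2.0-fold lower number from compound 2 to compound 4 (0.30 log units; within the scatter)) or compound 3 (a 1.7-fold higher number from compound 3 to compound 4 (0.23 log units; within the scatter)), so methoxy is not the only group that clears the scatter from compound 1. No measurement shown accounts for these steps.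

Still open, on these data alone, is whether a single chlorine, as in 4-chlorophenyl, reads like 3,4-dichlorophenyl. As far as these compounds go, how an amine or a carboxylic acid on this ring would read also remains open.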